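Aryl swap on the triazole: iodophenyl to methylphenyl

The source may hold more compounds than are shown below. What is called first, only, known or untested is meant among the compounds shown, and "the series" means these compounds.

Measured compounds:
Compound 1, `CC(C)n1ncc2c(C(=O)NC3CCCC3)cccc21`: > 40000 nM
Compound 2, `CC(C)n1ncc2c(C(=O)NCc3cn(-c4ccc(I)cc4)nn3)cccc21`: > 40000 nM

Both compounds share the same core and were tested in a functional assay on HepG2 cells (Homo sapiens) for inhibition, read by MTT assay, with a stated time of 72 h; on this read-out lower numbers stand for stronger inhibition and higher numbers for weaker inhibition. For compound 1 the result of > 40000 nM is a limit of the assay rather than a number. For compound 2 the result of > 40000 nM is likewise a limit and not a number. Where compound 2 stands, then, is only at the edge of what the assay can report, a point summed up by the limit of > 40000 nM in this assay, at which 2 of the 2 values shown sit.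

The next compound, compound 3, `Cc1cccc(-n2cc(CNC(=O)c3cccc4c3cnn4C(C)C)nn2)c1`, differs from compound 2 in one place: 3-methylphenyl in place of 4-iodophenyl on an aromatic nitrogen. Among the compounds with values here, no measured pair shows what such an exchange does here, and since compound 2 itself sits at the limit, nothing within the numbers gives a direction for this change. The most even-handed expectation is a step from compound 2 to compound 3 of no size beyond the scatter, a step that the limit leaves unreadable from compound 2 to compound 3, which most likely leaves compound 3 at the limit as well. Compound 3 is therefore estimated to give 50000 nM in this assay, within a range from 15000 nM to 150000 nM.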

Compound 3, half-maximal inhibitory concentration: > 40000 nM
Compound 3 was reported as a limit (the forecaster's own chance of this, stated with the estimate: 80%); the middle value lies beyond the limit too.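

The exchange of 4-iodophenyl for 3-methylphenyl cannot be read in this assay, because compound 2 and compound 3 both give a limit of the assay rather than a number: the limit of > 40000 nM in this assay, at which 3 of the 3 values shown sit.

The compounds shown leave open whether any change on the shared core would bring a result that the assay can report as a number.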